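The source may report more compounds than this note shows. Statements on the series, on what has been measured and on what is new or still open speak of the compounds shown alone.

Measured so far:
compound 1 `COc1cccc(NC(=O)c2nnn(Cc3cc(C)on3)c2N)c1` — in a physicochemical assay for solubility, read by nephelometry, at pH 7.4 (on this read-out lower numbers stand for lower solubility and higher numbers for higher solubility), compound 1 gives 174000 nM
compound 2 `COc1cccc(NC(=O)c2nnn(CC3CCNCC3)c2N)c1` — for compound 2 the result is only a limit of this assay, > 250000 nM
compound 3 `COc1cccc(NC(=O)c2nnn(Cc3ccc(SC)cc3)c2N)c1` — for compound 3 too the result is only a limit, < 12000 nM

Compound 3 stands lowest of the three, at the limit of < 12000 nM in this assay, at which 1 of the 3 values shown sits. Compound 4 `COc1cccc(NC(=O)c2nnn(Cc3ccc(OC(F)(F)F)cc3)c2N)c1` differs from it by trifluoromethoxy in place of methylsulfanyl on an aromatic carbon. Among the compounds with values here, no measured step alters a group on that ring. The two large steps of an at least 14-fold lower number from compound 1 to compound 3 (1.16 log units; beyond the scatter) and an at least 20-fold lower number from compound 2 to compound 3 (1.31 log units; beyond the scatter) each swap the whole group on the saturated chain carbon for 4-(methylsulfanyl)phenyl, so they do not speak to this smaller exchange. Because compound 3 already rests at the limit of < 12000 nM in this assay, at which 1 of the 3 values shown sits, a move beyond the scatter in either direction is not expected. Compound 4 is therefore estimated at 8000 nM, between 2500 nM and 25000 nM, a step that the limit leaves unreadable from compound 3 to compound 4 expected to stay small.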

Compound 4, solubility: 12000 nM
Compound 4: middle estimate off by 1.5-fold (0.18 log units), on the low side; low and high end bracket the measured number.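

This is the only step shown that alters a group on the ring itself, and in this assay it is a number no lower from compound 3 to compound 4 (the limit leaves the size open). Its size cannot be read, because compound 3 rests on a limit: the limit of < 12000 nM in this assay, at which 1 of the 4 values shown sits. Trifluoromethoxy on this aromatic carbon thus returns a true number where methylsulfanyl returned only a limit, yet the distance between the two groups stays unknown. The compounds shown leave open how far the true value of compound 3 lies from its limit, and how an amine or a carboxylic acid on this aromatic carbon would read.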